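This account rests on a few compounds, and the source may have more. Where it says the series, first, only, none or still open, it means among the compounds named here.

Measured in a physicochemical assay for acid dissociation:
- compound 1 `Cc1csc2cc([C@H](C)Nc3ncnc(N)c3C#N)c(-c3cccc(CN4CCC(N(C)CC(C)C)CC4)c3)c(=O)n12`: 9.7
- compound 2 `Cc1csc2cc([C@H](C)Nc3ncnc(N)c3C#N)c(-c3cccc(CN(C)CCCN(C)Cc4ccc(Cl)cc4)c3)c(=O)n12`: 8.8
- compound 3 `Cc1csc2cc([C@H](C)Nc3ncnc(N)c3C#N)c(-c3cccc(CN4CCC(N(C)CCC(F)(F)F)CC4)c3)c(=O)n12`: 7.3

Of the three, compound 2 stands second highest, below compound 1 and above compound 3, with both gaps beyond the scatter.

Compound 4 `Cc1csc2cc([C@H](C)Nc3ncnc(N)c3C#N)c(-c3cccc(CN(C)CCCCN4C[C@@H](C)O[C@@H](C)C4)c3)c(=O)n12` is compound 2 with one change: (2,6-dimethylmorpholin-4-yl)methyl in place of (4-chlorobenzyl)(methyl)amino on a saturated chain carbon, three bonds along the chain from an amine nitrogen. The amine nitrogen from which the chain is counted stays in place.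

Among the measured compounds shown here, only one measured step exists, a number 2.40 log units lower from compound 1 to compound 3 (beyond the scatter), a large step beyond the scatter. It puts 2,2,2-trifluoroethyl in place of isopropyl on a saturated chain carbon bound to an amine nitrogen. That is a different exchange at a different place, so it shows only that this series can move far in this assay and gives no size for the present change. The expectation therefore starts from compound 2 at 8.8.

No shift beyond the scatter is expected, with an estimated a number 0.10 log units higher from compound 2 to compound 4 (within the scatter). Compound 4 is expected at 8.9, with an estimated range of 8.3 to 9.5.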

Compound 4, acid dissociation constant: 8.9
Compound 4: middle estimate and measured number agree at the digits printed; low and high end bracket the measured number.
By their numbers in this assay, from the lowest: compound 3; then compounds 2 and 4 (each within the scatter of the next); then compound 1.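

In this assay, (2,6-dimethylmorpholin-4-yl)methyl in place of (4-chlorobenzyl)(methyl)amino on a saturated chain carbon, three bonds along the chain from an amine nitrogen, gives a number 0.10 log units higher from compound 2 to compound 4 (within the scatter). At this place, then, a six-membered non-aromatic ring with 2 hetero atoms can stand where a six-membered aromatic ring of carbon only stood, with the two numbers not told apart, whereas the earlier exchange at a different place gave a number 2.40 log units lower from compound 1 to compound 3 (beyond the scatter). Nothing available bears on what lies behind this result.

Still open, going by these compounds, is whether a carboxylic acid or a plain dimethylamino group on this same chain carbon would also stay within the scatter of compound 2. Also open, on these data alone, is how the unsubstituted morpholin-4-yl group would compare with its 2,6-dimethyl counterpart here.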